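The source may report more compounds than this note shows. Statements on the series, on what has been measured and on what is new or still open speak of the compounds shown alone.

In a functional assay on MCF7 cells (Homo sapiens) for inhibition, read by ATP content, with a stated time of 72 h (a higher number here means a weaker inhibitor, a lower number a stronger inhibitor), compound 1 (`Nc1ccccc1NC(=O)c1ccc(CNC2=N[C@@H](Cc3ccccc3)CS2)cc1`) gives 3090 nM and compound 2 (`Nc1ccccc1NC(=O)c1ccc(CNC2=NC(=O)C(c3ccccc3)N2)cc1`) gives 30100 nM as the highest of the two numbers, a gap beyond the scatter. Compound 3 (`Nc1ccccc1NC(=O)c1ccc(CNC2=NC(=O)C(Cc3ccccc3)N2)cc1`) changes compound 2 at one place, benzyl in place of phenyl on a saturated ring carbon. Among the measured compounds shown here, no measured step covers this change. A move to a lower number in this assay is expected because compound 1 with its benzyl gives 3090 nM on a different core. Only part of that gap is expected to carry over. The estimated step (a 3.0-fold lower number from compound 2 to compound 3 (0.48 log units; beyond the scatter)) is moderate and beyond the scatter. Compound 3 is estimated at 10000 nM (range 3500 nM to 30000 nM).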

Compound 3, half-maximal inhibitory concentration: > 50000 nM
Compound 3 was reported as a limit; the forecaster's own chance of this, stated with the estimate: 3%; middle value at least 5.0-fold (0.69 log units) from the limit.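

In this assay, benzyl in place of phenyl on the saturated ring carbon gives an at least 1.6-fold higher number from compound 2 to compound 3 (0.22 log units; that floor lies within the scatter), so on this core the change brings no gain. Compound 3 stands as a limit and not as a number: the limit of > 50000 nM in this assay, at which 1 of the 3 values shown sits. The step therefore has only a floor, and how far compound 3 lies from compound 2 remains unread. Open, as far as these compounds go, is whether an amine, a carboxylic acid or a longer chain on this ring carbon would give a lower number than compound 2. Also open, from the compounds shown here alone, is how phenyl would compare with benzyl on the core of compound 1.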